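A few compounds are considered here, and "the series" means these few. Any claim that something is new, unique, unknown or untested is made for them only; others in the source may bear on it.

Working notes on the series. Three measured analogues share one core and differ only in the group on a saturated chain carbon bound to an oxygen on an aromatic ring. In a functional assay on Mahlavu cells (Homo sapiens) for antiproliferative activity, read by sulforhodamine B assay, with a stated time of 72 h (a lower number here means a stronger inhibitor, a higher number a weaker inhibitor), compound 1 `Cc1ccccc1COc1ccc(-c2cc(CN3CCN(Cc4ccc(C(F)(F)F)cc4)CC3)no2)cc1` gives 6800 nM. Compound 2 `Cc1cc(C)cc(COc2ccc(-c3cc(CN4CCN(Cc5ccc(C(F)(F)F)cc5)CC4)no3)cc2)c1` gives 6000 nM. Compound 3 `N#Cc1ccc(COc2ccc(-c3cc(CN4CCN(Cc5ccc(C(F)(F)F)cc5)CC4)no3)cc2)cc1` gives 4300 nM. Among the measured compounds shown here, compound 2 stands second highest of the three numbers, and no step separates it from its neighbours beyond the scatter: a 1.1-fold lower number from compound 1 to compound 2 (0.05 log units; within the scatter), a 1.4-fold lower number from compound 2 to compound 3 (0.14 log units; within the scatter), and likewise a 1.6-fold lower number from compound 1 to compound 3 (0.20 log units; within the scatter).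

Compound 4 `COc1ccccc1COc1ccc(-c2cc(CN3CCN(Cc4ccc(C(F)(F)F)cc4)CC3)no2)cc1` differs from compound 2 in this way: 2-methoxyphenyl in place of 3,5-dimethylphenyl on a saturated chain carbon bound to an oxygen on an aromatic ring. Every measured step at this position stayed within the scatter, so in this assay no step beyond the scatter is expected from the change. Compound 4 is therefore expected near 5500 nM, with a range of 2500 nM to 12000 nM. The expected step is a 1.1-fold lower number from compound 2 to compound 4 (0.04 log units; within the scatter).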

Compound 4, half-maximal inhibitory concentration: 3900 nM
Beside the measured number, compound 4's estimate is 1.4-fold (0.15 log units) above it; the range from low to high includes it.
By their numbers in this assay, from the lowest: compounds 4, 3, 2 and 1 (each within the scatter of the next).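

The methoxy group brings no step beyond the scatter at this position in this assay, whether set against 3,5-dimethylphenyl (a 1.5-fold lower number from compound 2 to compound 4 (0.19 log units; within the scatter)) or 4-cyanophenyl (a 1.1-fold lower number from compound 3 to compound 4 (0.04 log units; within the scatter)). Even methoxy in place of methyl on an aromatic carbon (a 1.7-fold lower number from compound 1 to compound 4 (0.24 log units; within the scatter)), the largest step among the four compounds, stays within it, so the four groups cannot be ranked. No supporting data bear on these small steps.

Going by these compounds, whether an amine or a carboxylic acid at this position would move the number beyond the scatter remains open. So does the effect of a longer chain there.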